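One Fluorine Added Twice: Expectation for Compound 4

The source may hold more compounds than are shown below. What is called first, only, known or untested is meant among the compounds shown, and "the series" means these compounds.

Three compounds have been measured in a functional assay on MKN-45 cells (Homo sapiens) for cytotoxicity, read by MTT assay, with a stated time of 72 h; a lower number here means a stronger inhibitor, a higher number a weaker inhibitor:

Compound 1 `CCN(CC)CCCNc1nc(-c2ccc(NC(=O)Nc3ccccc3)cc2)nc2c(Cl)c(Cl)sc12` gives 1640 nM.
Compound 2 `CCN(CC)CCCNc1nc(-c2ccc(NC(=O)Nc3ccccc3)cc2)nc2ccsc12` gives 980 nM.
Compound 3 `CCN(CC)CCCNc1nc(-c2ccc(NC(=O)Nc3ccc(F)cc3)cc2)nc2c(Cl)c(Cl)sc12` gives 1700 nM.

Compound 1 and compound 3 share one core and differ by a single change, (fluoro in place of hydrogen on an aromatic carbon). That change produced a 1.0-fold higher number from compound 1 to compound 3 (0.02 log units; within the scatter), a step that the study treats as no movement at all. Compound 2 carries a different core; the difference between the two cores is not broken down here, and its value stands close to those of compound 1 and compound 3, with all three numbers falling within the usual scatter of one another.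

Compound 4 `CCN(CC)CCCNc1nc(-c2ccc(NC(=O)Nc3ccc(F)cc3)cc2)nc2ccsc12` has not yet been measured in this assay. It is related to compound 2 exactly as compound 3 is related to compound 1: the change is fluoro in place of hydrogen on an aromatic carbon, at the same place, described in the same words for both pairs, so this is the same change rather than merely the same kind of change.

Because the earlier instance gave a 1.0-fold higher number from compound 1 to compound 3 (0.02 log units; within the scatter), the expectation for compound 4 is that the fluoro adds nothing measurable in this assay and that the step from compound 2 will read a 1.0-fold higher number from compound 2 to compound 4 (0.01 log units; within the scatter). For the measured compounds named here, the single precedent rests on one pair and one core, so the range is kept wide. Compound 4 is estimated at 1000 nM, expected to fall between 500 nM and 2000 nM.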

Compound 4, half-maximal inhibitory concentration: 470 nM
Beside the measured number, compound 4's estimate is 2.1-fold (0.33 log units) above it; measured number outside the range, below it.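

In this assay, replacing phenyl with 4-fluorophenyl on the core of compound 2 gave a 2.1-fold lower number from compound 2 to compound 4 (0.32 log units; beyond the scatter), a modest step but one that lies beyond the scatter, whereas the same replacement on the core of compound 1 had left the number in place. Set side by side, however, the two steps cannot be told apart, since the gap between them does not exceed what two such steps can differ by through scatter alone: the same change on two cores in this assay, a 1.0-fold higher number (0.02 log units; within the scatter) from compound 1 to compound 3 and a 2.1-fold lower number (0.32 log units; beyond the scatter) from compound 2 to compound 4, 2.2-fold (0.33 log units) apart, within the scatter of two such steps The result therefore shows that the fluoro can give a measurable gain on at least one of these cores, but it does not show that the core governs the size of the step, nor that the change carries over unaltered, as each core is represented by a single pair.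

The compounds shown leave open whether another group on the same ring carbon, such as chloro, methoxy or trifluoromethyl, would move the number on either core. They also leave open whether the fluoro step would hold if a morpholine or a pyrrolidine replaced the diethylamine of the side chain.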